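From methoxy to 4-chlorophenyl on the shared core

The source may hold more compounds than are shown below. What is called first, only, known or untested is meant among the compounds shown, and "the series" means these compounds.

In a functional assay on CCRF-CEM cells (Homo sapiens) (a lower number here means a stronger inhibitor, a higher number a weaker inhibitor), compound 1 `Nc1ncnc2c1ncn2C[C@@H]1C[C@H](CO)c2ccccc21` gives 24 ug/mL and compound 2 `Cc1ccc(-c2ncnc3c2ncn3C[C@@H]2C[C@H](CO)c3ccccc32)cc1` gives 1.4 ug/mL. Compound 3 `COc1ncnc2c1ncn2C[C@@H]1C[C@H](CO)c2ccccc21` gives 24 ug/mL, level with compound 1, the two sharing the highest of the three numbers. Compound 4 `OC[C@H]1C[C@@H](Cn2cnc3c(-c4ccc(Cl)cc4)ncnc32)c2ccccc21` is still unmeasured. It carries 4-chlorophenyl in place of methoxy on an aromatic carbon of the shared core: 4-chlorophenyl in place of methoxy on an aromatic carbon.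

Among the measured compounds shown here, two measured steps bear most directly on this change. Placing 4-methylphenyl in place of amino gave a large step, a 17-fold lower number from compound 1 to compound 2 (1.23 log units; beyond the scatter), and methoxy in place of 4-methylphenyl reversed it, a 17-fold higher number from compound 2 to compound 3 (1.23 log units; beyond the scatter). Methoxy in place of amino, by contrast, stayed within the scatter, no change at the digits printed from compound 1 to compound 3 (within the scatter). For the measured compounds named here, the only aryl group measured so far thus gives the one low number, although no chlorinated aryl group has been tested. A similarly large step toward a lower number is therefore expected, a 16-fold lower number from compound 3 to compound 4 (1.20 log units; beyond the scatter). The estimated value for compound 4 is 1.5 ug/mL, with an expected range of 0.6 ug/mL to 4.5 ug/mL.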

Compound 4, half-maximal inhibitory concentration: 0.63 ug/mL
Beside the measured number, compound 4's estimate is 2.4-fold (0.38 log units) above it; low and high end bracket the measured number.
By their numbers in this assay, from the lowest: compound 4; then compound 2; then compounds 1 and 3 (each within the scatter of the next).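

In this assay the low number at this position no longer rests on a single aryl group: 4-chlorophenyl gives a 38-fold lower number from compound 3 to compound 4 (1.58 log units; beyond the scatter) and a 38-fold lower number from compound 1 to compound 4 (1.58 log units; beyond the scatter) and so stands far from both methoxy and amino. The two aryl groups can also be told apart, as chloro in place of methyl on an aromatic carbon gives a 2.2-fold lower number from compound 2 to compound 4 (0.35 log units; beyond the scatter) and is a modest step beyond the scatter. Among these four compounds, the step from methoxy or amino to an aryl group is thus much larger than the step between the two aryl groups.

Nothing measured here accounts for these steps. Going by these compounds, it remains open whether an unsubstituted phenyl, a 4-fluorophenyl or a pyridine ring would match 4-chlorophenyl at this position, and whether a piperidine ring would fall with amino and methoxy.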